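The source may hold more compounds than are shown below. What is called first, only, known or untested is meant among the compounds shown, and "the series" means these compounds.

Three thiourea-bearing compounds have been examined in an ADME assay on Huh-7 cells (Homo sapiens) for cytotoxicity; a higher number here means that more compound is tolerated, a lower number that less compound is tolerated. Compound 1 `NC(=S)Nc1cccc(OCCCCCN2CCN(c3ccc(Cl)cc3)C2=O)c1` gives 39000 nM in this assay. Compound 2 `Cc1ccc(OCCCCCNC(=S)Nc2cccc3ccccc23)cc1NC(N)=S` gives in this assay only a limit, > 50000 nM, which is a bound of the measurement and not a number. Compound 3 `NC(=S)Nc1cccc(OCCCCCCCCNC(=S)Nc2cccc(Br)c2)c1` gives 20000 nM in this assay. Between compound 3 and compound 1 the gap lies within the usual scatter of the measurement, so neither can be placed above or below the other; the third value is a limit, as noted in the limit of > 50000 nM in this assay, at which 1 of the 3 values shown sits.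

The step to compound 4 `NC(=S)Nc1cccc(OCCCCCCCCNC(=S)Nc2ccc3c(c2)CCC3)c1` is 2,3-dihydro-1H-inden-5-yl in place of 3-bromophenyl on an amide-type nitrogen. Among the measured compounds shown here, no pair of measured compounds differs in one place, so no measured step guides the expectation. The move from 3-bromophenyl to 2,3-dihydro-1H-inden-5-yl on the amide-type nitrogen is not expected to shift tolerance beyond the scatter, and the step from compound 3 to compound 4 is estimated as a 1.3-fold higher number from compound 3 to compound 4 (0.10 log units; within the scatter). Compound 4 is therefore expected to give about 25000 nM in this assay, with a range from 10000 nM to 50000 nM.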

Compound 4, half-maximal cytotoxic concentration: 34000 nM
For compound 4 the middle estimate is 1.4-fold (0.13 log units) below the measured one; the measured number falls inside the stated range.
By their numbers in this assay, from the lowest: compounds 3, 4 and 1 (each within the scatter of the next). At a limit, above all of these: compound 2.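

Among the compounds shown here, compounds 1 to 3 offered no pair differing in one place, so this is the only single change that can be read in this assay: a 1.7-fold higher number from compound 3 to compound 4 (0.23 log units; within the scatter). On the amide-type nitrogen, then, 2,3-dihydro-1H-inden-5-yl and 3-bromophenyl cannot be told apart in tolerance, even though the bromine leaves and a five-membered non-aromatic ring of carbon only enters. Nothing in the data bears on a cause for this step.

As far as these compounds go, whether a phenyl carrying an amine or a carboxylic acid on this same nitrogen would move the number beyond the scatter remains open. Also open, from the compounds shown here alone, is what a shorter chain would do with either of these two groups in place, since compound 3 and compound 4 share one chain.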